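Removing a nitro group from an ester side chain

This account rests on a few compounds, and the source may have more. Where it says the series, first, only, none or still open, it means among the compounds named here.

Measured compounds:
compound 1 `CC(C)[C@H]1CC[C@@]2(CO2)[C@H]2C(=O)OCC(C(=O)OCc3ccc(-c4ccc([N+](=O)[O-])cc4)o3)=C[C@H]12` gives 1190 nM
compound 2 `C=C(C(=O)O)C1OC(=O)[C@H]2[C@H]1[C@@H](C(C)C)CC[C@@]2(O)CI` gives > 10000 nM

In a functional assay on NAMALVA cells (Homo sapiens) for inhibition, with a stated time of 72 h (on this read-out higher numbers stand for weaker inhibition and lower numbers for stronger inhibition), compound 1 gives 1190 nM, the only plain number shown. Among the compounds with values here, for compound 2 the value > 10000 nM is a limit of the assay, not a number, and no other compound shares its shape closely enough to compare (the limit of > 10000 nM in this assay, at which 1 of the 2 values shown sits). No step between measured compounds that differ in one place is shown, so nothing measured tells how a single change shifts this read-out.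

Compound 3 `CC(C)[C@H]1CC[C@@]2(CO2)[C@H]2C(=O)OCC(C(=O)OCc3ccc(-c4ccccc4)o3)=C[C@H]12` is not yet measured. It differs from compound 1 in one place (hydrogen in place of nitro on an aromatic carbon), which can also be read as 4-nitrophenyl to phenyl. Since the shared core and the rest of the ester side chain stay the same, a small shift in this assay, close to the scatter and probably toward weaker inhibition, is expected. Compound 3 is therefore estimated at 2000 nM (range 700 nM to 6000 nM), meaning an expected step of a 1.7-fold higher number from compound 1 to compound 3 (0.23 log units; within the scatter).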

Compound 3, half-maximal inhibitory concentration: 370 nM
Beside the measured number, compound 3's estimate is 5.4-fold (0.73 log units) above it, and the stated range ends above it.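

In this assay, replacing the nitro group with hydrogen gives a 3.2-fold lower number from compound 1 to compound 3 (0.51 log units; beyond the scatter), a step beyond the usual scatter and toward stronger inhibition. Within the data shown here, this is the first sign that this place, on an aromatic carbon para to a large group, matters for the read-out, and that the nitro group is not needed for inhibition, since the plain phenyl compound does better. Nothing shown explains why the number moves.

On these data alone, only nitro and hydrogen have been compared at this place, so it remains open whether an amine or a methoxy group there would lower the number further or raise it. As far as these compounds go, it is equally open whether the same change would give a similar step on a different core.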